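Compound 4: fluoro in place of methoxy

The compounds below may be only part of what the source reports. "The series", "measured", "known", "first", "only" and "open" are said of these compounds alone.

Measured so far in an ADME assay on SH-SY5Y cells (Homo sapiens) for cytotoxicity, read by MTT assay, with a stated time of 72 h; a higher number here means a weaker inhibitor, a lower number a stronger inhibitor
- compound 1 `COc1ccc(C(=O)N2CCN(CC(=O)N3CCN(CCCc4c[nH]c5ccccc45)CC3)CC2)cc1` gives 148000 nM
- compound 2 `O=C(CN1CCN(C(=O)c2ccc(Br)cc2)CC1)N1CCN(CCCc2c[nH]c3ccccc23)CC1` gives 59300 nM
- compound 3 `COc1cccc(C(=O)N2CCN(CC(=O)N3CCN(CCCc4c[nH]c5ccccc45)CC3)CC2)c1` gives > 200000 nM as a limit

Compound 3 stands at the limit of > 200000 nM in this assay, at which 1 of the 3 values shown sits, and so has a limit, not a number. Compound 4 `O=C(CN1CCN(C(=O)c2cccc(F)c2)CC1)N1CCN(CCCc2c[nH]c3ccccc23)CC1` differs from compound 3 as follows fluoro in place of methoxy on an aromatic carbon and the change is fluoro in place of methoxy on an aromatic carbon, meta to a large group. The closest measured change is a 2.5-fold lower number from compound 1 to compound 2 (0.40 log units; beyond the scatter) and it also swaps methoxy for a halogen, though bromo, not fluoro, and in a 4-bromophenyl group. The step of an at least 3.3-fold higher number from compound 2 to compound 3 (0.52 log units; beyond the scatter) points the same way. The step of an at least 1.3-fold higher number from compound 1 to compound 3 (0.13 log units; that floor lies within the scatter) has a floor within the scatter. A modest move to a lower number is therefore expected in this assay and a reading at the limit remains possible. The expected step is an at least 1.8-fold lower number from compound 3 to compound 4 (0.25 log units; that floor lies within the scatter) and it rests on a single halogen precedent. The estimate for compound 4 is 110000 nM with 50000 nM to 200000 nM as the expected range.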

Compound 4, half-maximal inhibitory concentration: 165000 nM
The estimate for compound 4 lay 1.5-fold (0.18 log units) below the measured number, and the stated range covers the measured number.
By their numbers in this assay, from the lowest: compound 2; then compounds 1 and 4 (each within the scatter of the next). At a limit, above all of these: compound 3.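

In this assay, fluoro in place of methoxy on an aromatic carbon, meta to a large group, gives an at least 1.2-fold lower number from compound 3 to compound 4 (0.08 log units; that floor lies within the scatter) and the true size of this change stays unfixed because compound 3 has only a limit, not a number: the limit of > 200000 nM in this assay, at which 1 of the 4 values shown sits.

Compound 4 gives this position its first number, and 3-fluorophenyl in place of 4-methoxyphenyl gives a 1.1-fold higher number from compound 1 to compound 4 (0.05 log units; within the scatter) so that pair cannot be separated. 3-fluorophenyl in place of 4-bromophenyl gives a 2.8-fold higher number from compound 2 to compound 4 (0.44 log units; beyond the scatter) so a halogen on the ring does not by itself bring compound 4 to the number of compound 2.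

Open, on these data alone, is whether the halogen or its place sets that gap, a question that 3-bromophenyl or 4-fluorophenyl would address. Also open, as far as these compounds go, is how an amine or a carboxylic acid at this place would read in this assay.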